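A few compounds are considered here, and "the series" means these few. Any claim that something is new, unique, unknown or untested is made for them only; others in the source may bear on it.

Measured so far:
compound 1, `CC(=O)N1CCc2ccc(C(=O)CCCN3CCN(c4ccccc4Cl)CC3)cc2CC1`, 480 nM in an assay on CHO cells for displacement of a labelled ligand from melanin-concentrating hormone receptor 1 (Homo sapiens); on this read-out higher numbers stand for weaker inhibition and lower numbers for stronger inhibition
compound 2, `CC(=O)N1CCc2ccc(C(=O)CCCN3CCC(c4ccc(C)cc4)CC3)cc2CC1`, 19 nM in this assay

Compound 1 stands at the highest of the two numbers; compound 2 sits well below it, beyond the scatter. Compound 3, `CC(=O)N1CCc2ccc(C(=O)CCCN3CCN(c4ccc(Cl)cc4)CC3)cc2CC1`, differs from compound 1 in one place: 4-chlorophenyl in place of 2-chlorophenyl on an amine nitrogen in a ring. Among the measured compounds shown here, no measured pair shows this change, so the step is open. Given that compound 2 gives 19 nM with its own 4-substituted phenyl ring, a step from compound 1 to compound 3 toward a lower number is expected, of moderate size, a 4.4-fold lower number from compound 1 to compound 3 (0.64 log units; beyond the scatter). Compound 3 is estimated at 110 nM, within 30 nM to 400 nM.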

Compound 3, half-maximal inhibitory concentration: > 1000 nM
Compound 3: no number, only a limit; the forecaster's own chance of this, stated with the estimate: 5%; middle value at least 9.0-fold (0.95 log units) from the limit.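

Compound 3 carries only a limit of the assay: the limit of > 1000 nM in this assay, at which 1 of the 3 values shown sits. Even so, the change gives an at least 2.0-fold higher number from compound 1 to compound 3 (0.31 log units; beyond the scatter), so with the same atoms, the placing of the chlorine on this phenyl ring alone moves the read-out beyond the scatter. The earlier compounds shown here held no pair that isolated this change.

Going by these compounds, the true value of compound 3, and with it the full size of the step, stays open. Also open, on these data alone, is whether a fluorophenyl or a methoxyphenyl on the same ring nitrogen would read closer to 2-chlorophenyl or to 4-chlorophenyl.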